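The compounds below may be only part of what the source reports. "The series", "measured", "known", "first", "only" and "open" are said of these compounds alone.

Measured in an ADME assay on microsomes from liver (Mus musculus) for metabolic stability; on this read-out higher numbers stand for a longer-lived compound and lower numbers for a shorter-lived compound:
- compound 1 `CC(C)C(Cc1nnc[nH]1)c1ccc(-c2ccc3cccc(F)c3c2)[nH]c1=O`: < 0.0667 h (a limit)
- compound 2 `CCn1ncc2c(F)cc(-c3ccc(C(CC)(CC)c4nncn4C)c(=O)[nH]3)cc21`: > 3 h (a limit)
- compound 3 `CCC(CC)(c1nnc[nH]1)c1ccc(-c2ccc3cccc(F)c3c2)[nH]c1=O`: 0.447 h

Only compound 3 has an exact number here. Compound 1 stands at the short-lived end of this set, and its result is the limit of < 0.0667 h in this assay, at which 1 of the 3 values shown sits. Compound 2 stands at the long-lived end, and its result is the limit of > 3 h in this assay, at which 1 of the 3 values shown sits.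

Compound 4 `CC(C)C(c1ncc[nH]1)c1ccc(-c2ccc3cccc(F)c3c2)[nH]c1=O` differs from compound 1 in one place: 1H-imidazol-2-yl in place of (4H-1,2,4-triazol-3-yl)methyl on a saturated chain carbon bound to an aromatic carbon and a saturated chain carbon. It has 1H-imidazol-2-yl in place of (4H-1,2,4-triazol-3-yl)methyl on a saturated chain carbon bound to an aromatic carbon and a saturated chain carbon. The rest of the structure stays the same.

Within the data shown here, no measured pair of compounds shows what a single change of this kind does in this assay, so the expectation starts from compound 1 itself. The starting point is a limit, since compound 1 gives < 0.0667 h. Little movement is expected, with no step beyond the usual scatter, and any shift is more likely to be upward than downward. The expected change is an at least 1.0-fold higher number from compound 1 to compound 4 (0.02 log units; that floor lies within the scatter). Compound 4 may well be reported only as a limit too. The estimate for compound 4 is 0.07 h, with an expected range from 0.03 h to 0.25 h.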

Compound 4, half-life: < 0.0667 h
Compound 4 ended at the assay's limit (the forecaster's own chance of this, stated with the estimate: 55%); at least 1.0-fold (0.02 log units) between middle value and limit.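

Compound 1 and compound 4 both end at the same limit of the assay, not at exact numbers, so the step between them cannot be read: the limit of < 0.0667 h in this assay, at which 2 of the 4 values shown sit.

The compounds shown leave open whether 1H-imidazol-2-yl in place of (4H-1,2,4-triazol-3-yl)methyl changes the half-life at all, and in which direction.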